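Trimming the Acyl Group on a Piperidine Carboxamide

A few compounds are considered here, and "the series" means these few. Any claim that something is new, unique, unknown or untested is made for them only; others in the source may bear on it.

Of the compounds shown here, three have so far been measured in an ADME assay on microsomes (Rattus norvegicus) for metabolic stability; a lower number here means that the compound disappears faster, a higher number that the compound lasts longer. Compound 2 `O=C(c1cscn1)N1CCC(C(=O)N2N=CC[C@H]2c2ccccc2)CC1` gives the highest number of the three, a half-life of 0.65 h in this assay. Compound 1 `C[C@@H]1C=NN(C(=O)C(C)(C)C)[C@@H]1c1ccccc1` shows 0.2 h in this assay, a lower number than that of compound 2 and beyond the scatter of the measurement. Compound 3 `CC(C)(C)C(=O)N1CCSC1c1ccccc1` lies furthest away with 0.0533 h in this assay, a lower number than that of compound 2, also beyond the scatter. No pair among these three differs in a single place, so no step between measured compounds can be read off.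

The next compound, compound 4 `CC(=O)N1CCC(C(=O)N2N=CC[C@H]2c2ccccc2)CC1`, differs from compound 2 in exactly one place: methyl in place of 1,3-thiazol-4-yl on a carbonyl carbon. For the measured compounds named here, no measured pair carries this difference. Going by the values given here, nothing among the measured compounds therefore shows what such an exchange does to the half-life in this assay. Compound 2 stands as the only anchor.

With no guidance from the data in either direction, the step from compound 2 to compound 4 is expected to stay within the usual scatter, a 1.1-fold higher number from compound 2 to compound 4 (0.03 log units; within the scatter). For compound 4 the half-life in this assay is estimated at 0.7 h, with a likely range from 0.3 h to 1.6 h.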

Compound 4, half-life: > 2.75 h
Compound 4: no number, only a limit; the forecaster's own chance of this, stated with the estimate: 5%; middle value at least 3.9-fold (0.59 log units) away from the limit.
By their numbers in this assay, from the lowest: compound 3; then compound 1; then compound 2. At a limit, above all of these: compound 4.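

In this assay, for the compounds shown here, the exchange at this one position gives an at least 4.2-fold higher number from compound 2 to compound 4 (0.62 log units; beyond the scatter), the only step among the four compounds that isolates a single change. It shows that the carbonyl carbon whose other neighbour is the amide-type nitrogen in a ring is a place where the acyl group matters for the half-life, something the three earlier compounds could not show, since none of them formed a pair. It also shows that the 1,3-thiazol-4-yl group is not needed to keep the half-life at this position, as the much smaller methyl goes with a higher number, and that reading rests on a limit rather than a number: the limit of > 2.75 h in this assay, at which 1 of the 4 values shown sits.

What the compounds leave open is whether the higher number goes with the loss of the aromatic ring or with the smaller count of heavy atoms, since this one step changes both at once. From the compounds shown here alone, how an ethyl, a cyclopropyl or a phenyl group on the same carbonyl carbon would fall relative to methyl and 1,3-thiazol-4-yl also remains unknown, as does the effect of a group carrying an amine or a carboxylic acid there.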